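Swapping Chloro for Bromo in a Cytotoxicity Screen

A few compounds are considered here, and "the series" means these few. Any claim that something is new, unique, unknown or untested is made for them only; others in the source may bear on it.

Compound 1 `O=C(/C=C/c1cc(F)cc(F)c1O)c1ccccc1`: 37.4%
Compound 2 `Cc1ccc(C(=O)/C=C/c2cc(Cl)ccc2O)cc1`: 33.5%

In an ADME assay on MCF-10A cells (Homo sapiens) for cytotoxicity, read by sulforhodamine B assay, with a stated time of 72 h, tested at 10 uM (a lower number here means a weaker effect, a higher number a stronger effect of the compound at the concentration tested), compound 1 gives 37.4% and compound 2 gives 33.5%. Compound 2 stands alongside compound 1, the two numbers falling within the usual scatter of each other, so nothing separates them. Compound 3 `Cc1ccc(C(=O)/C=C/c2cc(Br)ccc2O)cc1` differs from compound 2 by a single change: bromo in place of chloro on an aromatic carbon. Going by the values given here, no measured pair shows this exchange, so the step in this assay is expected to be small, at most the scatter, and the estimate a number 2.5 percentage points higher from compound 2 to compound 3 (within the scatter) reflects that. Compound 3 is therefore estimated at 36%, with a range from 24% to 50%.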

Compound 3, a percentage reported as activity, at one concentration (the size of the read-out at that concentration, not a potency): 32.4%
Estimate against measurement, compound 3: 3.6 percentage points above; the range from low to high includes it.
By their numbers in this assay, from the lowest: compounds 3, 2 and 1 (each within the scatter of the next).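

In this assay, going by these compounds alone, bromo in place of chloro on this aromatic carbon, para to a hydroxy group, gives a number 1.1 percentage points lower from compound 2 to compound 3 (within the scatter), the first step that changes one place only. At this position, the two halogens therefore cannot be told apart in this read-out. Nothing available accounts for this result. From the compounds shown here alone, whether an amine or a carboxylic acid on the same carbon would give a step beyond the scatter remains open. So does whether this exchange would behave alike on the core of compound 1.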